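The source may report more compounds than this note shows. Statements on the series, on what has been measured and on what is new or still open speak of the compounds shown alone.

Measured so far:
Compound 1 `CCN(CC)C(=S)SCC1=CCOC1=O` — in a functional assay on PC-3 cells (Homo sapiens) for antiproliferative activity, read by MTT assay, with a stated time of 72 h (a higher number here means a weaker inhibitor, a lower number a stronger inhibitor), compound 1 gives 57100 nM
Compound 2 `CN(C)C(=S)SCC1=CCOC1=O` — in this assay compound 2 gives 147000 nM

Compound 2 stands with the highest of the two numbers in this assay; its nearest neighbour is compound 1, and the step of a 2.6-fold higher number from compound 1 to compound 2 (0.41 log units; beyond the scatter) is beyond the scatter. Compound 3 `O=C1OCC=C1CSC(=S)N1CCCC1` is not yet measured. It differs from compound 2 in one place: pyrrolidin-1-yl in place of dimethylamino on a thiocarbonyl carbon. Going by the values given here, only one measured step bears on this change, the step of a 2.6-fold higher number from compound 1 to compound 2 (0.41 log units; beyond the scatter), in which the smaller dimethylamino group gave a higher number than diethylamino. Pyrrolidin-1-yl brings back a group of the same carbon count as diethylamino, now closed into a ring, so the number for compound 3 is expected to fall back toward that of compound 1, roughly reversing that step. The estimated result for compound 3 in this assay is 70000 nM, within 30000 nM to 170000 nM, a step of a 2.1-fold lower number from compound 2 to compound 3 (0.32 log units; beyond the scatter).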

Compound 3, half-maximal inhibitory concentration: 114000 nM
The estimate for compound 3 lay 1.6-fold (0.21 log units) below the measured number, and the stated range covers the measured number.
By their numbers in this assay, from the lowest: compounds 1, 3 and 2 (each within the scatter of the next, the first and the last beyond it).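

In this assay, pyrrolidin-1-yl gives a 1.3-fold lower number from compound 2 to compound 3 (0.11 log units; within the scatter), and in place of diethylamino it gives a 2.0-fold higher number from compound 1 to compound 3 (0.30 log units; within the scatter), so the ring cannot be told apart from either open-chain group on the thiocarbonyl carbon. The earlier pair, with a 2.6-fold higher number from compound 1 to compound 2 (0.41 log units; beyond the scatter), hinted that the larger group gives the lower number, but compound 3 neither confirms nor refutes that reading, and all three numbers remain close together. Nothing measured here gives a reason for these numbers.

On these data alone, whether a piperidin-1-yl or morpholin-4-yl ring, or a longer chain such as dibutylamino, would move the number beyond the scatter remains open. Also open, as far as these compounds go, is how much the thiocarbonyl unit and the shared core contribute, as all three compounds carry both.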